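Alkyl chain returns to the triazole of the quinoline series

The compounds below may be only part of what the source reports. "The series", "measured", "known", "first", "only" and "open" are said of these compounds alone.

Measured so far:
- compound 1, `CCCCCCCc1cn(C(c2ccccc2)c2cc3cc(Br)ccc3nc2OC)nn1`: 10.5%
- compound 2, `COc1nc2ccc(Br)cc2cc1C(c1ccccc1)n1cc(-c2ccccc2F)nn1`: 7.33%

Both numbers come from an ADME assay on SK-OV-3 cells (Homo sapiens) for cytotoxicity, read by sulforhodamine B assay, with a stated time of 48 h, tested at 10 uM; on this read-out lower numbers stand for less inhibition and higher numbers for more inhibition at the one concentration tested (going by the name of the read-out). Compound 2 stands with 7.33% beside a single neighbour: compound 1, whose value lies within the scatter of it, so the two compounds are not separated on this read-out.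

Compound 3, `CCCCCc1cn(C(c2ccccc2)c2cc3cc(Br)ccc3nc2OC)nn1`, is not yet measured. It differs from compound 2 at one place: pentyl in place of 2-fluorophenyl on an aromatic carbon. Among the measured compounds shown here, the only measured step that touches this position is a number 3.2 percentage points lower from compound 1 to compound 2 (within the scatter), which swapped a heptyl for the 2-fluorophenyl and moved the read-out by an amount within the scatter. Compound 3 goes back to a chain, pentyl, two carbons shorter than the heptyl of compound 1. For the measured compounds named here, with the one relevant step showing no movement beyond the scatter, nothing here points to a direction; the expectation is a step of a number 1.7 percentage points higher from compound 2 to compound 3 (within the scatter) that stays within the scatter.

Compound 3 is therefore estimated at 9%, with a range from 0% to 20%.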

Compound 3, a percentage reported as inhibition, at one concentration (the size of the read-out at that concentration, not a potency): 10.5%
Compound 3: middle estimate off by 1.5 percentage points, on the low side; measured number inside the range.
By their numbers in this assay, from the lowest: compounds 2, 1 and 3 (each within the scatter of the next).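

In this assay, the return from 2-fluorophenyl to a chain gives a number 3.2 percentage points higher from compound 2 to compound 3 (within the scatter) and so stays as small as the earlier swap at this aromatic carbon of the triazole. The new comparison is between chain lengths, with pentyl in place of heptyl giving no change at the digits printed from compound 1 to compound 3 (within the scatter) and thus no separation on this read-out between the two chains. Together, the three compounds show that neither a chain against a six-membered aromatic ring nor this shortening of the chain separates the values at this position, and no measurement at hand offers a reason for that.

Still open, on these data alone, is whether any group at this carbon can move the read-out beyond the usual scatter, since the heptyl, pentyl and 2-fluorophenyl compounds do not define a trend in either direction. A primary amine or a carboxylic acid at the end of the chain, or a chain longer than heptyl, would probe this position with groups unlike those shown, and the effect of changes elsewhere on the shared core also remains unknown.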